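Ethyl Ester in Place of the Acid: Compound 3

This account rests on a few compounds, and the source may have more. Where it says the series, first, only, none or still open, it means among the compounds named here.

Measured so far:
- Compound 1, `CCCCC(Sc1nc(Cl)cc(Nc2ccc3ncccc3c2)n1)C(=O)OCC`: 51.8%
- Compound 2, `CCCCCCC(Sc1nc(Cl)cc(Oc2ccc3ncccc3c2)n1)C(=O)O`: 91.4%

In an assay for inhibition of Polyunsaturated fatty acid 5-lipoxygenase (Homo sapiens), tested at 1 uM (a lower number here means a stronger effect, a higher number a weaker effect of the compound at the concentration tested), compound 2 gives 91.4%, the highest of the two numbers seen so far. Its nearest neighbour is compound 1, which in this assay gives 51.8%, a value lower by a gap that lies beyond the usual scatter. Among the measured compounds shown here, compound 1 and compound 2 differ in more than one place, so no single step connects them; only their two values stand side by side.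

Compound 3, `CCCCCCC(Sc1nc(Cl)cc(Oc2ccc3ncccc3c2)n1)C(=O)OCC`, has not yet been measured. It differs from compound 2 in one place: ethyl in place of hydrogen on an oxygen next to a carbonyl group. Read one bond further out, a carboxy group becomes an ethoxycarbonyl group. For the measured compounds named here, no measured pair shows what this change does on this core, so the expectation rests loosely on the two values seen. Compound 3 is expected to show a step of a number 21.4 percentage points lower from compound 2 to compound 3 (beyond the scatter) in this assay, towards the stronger side. For compound 3 in this assay the estimated value is 70%, within a range from 40% to 100%.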

Compound 3, a percentage reported as activity, at one concentration (the size of the read-out at that concentration, not a potency): 67.4%
Beside the measured number, compound 3's estimate is 2.6 percentage points above it; the measured number falls inside the stated range.
By their numbers in this assay, from the lowest: compound 1; then compound 3; then compound 2.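

Among the compounds shown here, this is the first pair that differs in one place only, so a single change can be read on its own. In this assay, putting ethyl in place of the hydrogen turns the carboxy group into an ethoxycarbonyl group and gives a number 24 percentage points lower from compound 2 to compound 3 (beyond the scatter) as a modest move towards the stronger side, a shift that lies beyond the usual scatter. The free acid is therefore not needed for the effect seen at this concentration on this core, and this one position alone is enough to change the read-out, though nothing available here explains why the change acts in this direction.

As far as these compounds go, whether a methyl ester, a bulkier ester such as tert-butyl, or an amide on the same carbonyl would move the number further, or back towards that of the acid, stays open. From the compounds shown here alone, it is also open whether the same change would give a step of similar size on the core of compound 1, since a single pair on a single core cannot show how general this step is.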